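The source may report more compounds than this note shows. Statements on the series, on what has been measured and on what is new or still open speak of the compounds shown alone.

Compound 1 `O=C(NCCO)c1c(NO)cc(-c2ccc(F)cc2)oc1=O`: > 20000 nM
Compound 2 `O=C(NCCO)c1c(NO)cc(-c2ccc(Cl)cc2)oc1=O`: > 20000 nM

In an ADME assay on Huh-7 cells (Homo sapiens) for cytotoxicity, read by a luciferase reporter and WST assay, with a stated time of 3 days (on this read-out higher numbers stand for lower toxicity in this test and lower numbers for higher toxicity in this test), compound 1 gives > 20000 nM, a limit of the assay rather than a number. In this assay compound 2 gives > 20000 nM, also a limit. The step that the two limits leave unreadable from compound 1 to compound 2 therefore cannot be read. Both values sit at the limit of > 20000 nM in this assay, at which 2 of the 2 values shown sit. Compound 3 `O=C(NCc1ccccc1)c1c(NO)cc(-c2ccc(F)cc2)oc1=O` differs from compound 1 by phenyl in place of hydroxymethyl on a saturated chain carbon bound to an amide-type nitrogen. For the measured compounds named here, no measured step bears on this change, and compound 1 itself offers only a limit, so no direction can be drawn from the numbers. Compound 3 is expected to land at 20000 nM, within 7000 nM to 40000 nM, a step of a number no higher from compound 1 to compound 3 (the limit leaves the size open).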

Compound 3, half-maximal cytotoxic concentration: > 20000 nM
Compound 3: a limit, no number; the forecaster's own chance of this, stated with the estimate: 65%; the middle value sits exactly at the limit.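

In this assay, for the compounds shown here, compound 3 gives > 20000 nM, a limit and not a number, so no step from compound 1 to compound 3 can be read. The compounds shown leave open where the true values of compound 1, compound 2 and compound 3 lie, and whether either change shifts them: the limit of > 20000 nM in this assay, at which 3 of the 3 values shown sit.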